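The source may hold more compounds than are shown below. What is called first, only, known or untested is meant among the compounds shown, and "the series" means these compounds.

Measured so far, in a functional assay on A549 cells (Homo sapiens) for cytotoxicity, read by MTT assay, with a stated time of 48 h; on this read-out lower numbers stand for stronger inhibition and higher numbers for weaker inhibition:
- compound 1 `COc1cc(-c2nnc3n2NC(c2ccco2)C(C(=O)C2CC2)S3)cc(OC)c1OC` — > 100000 nM, a limit of the assay
- compound 2 `COc1cc(-c2nnc3n2NC(c2ccco2)C(C(=O)c2ccc(C)cc2)S3)cc(OC)c1OC` — > 100000 nM, a limit of the assay

Compound 2 therefore stands only at a limit on the numbers shown. The step that the two limits leave unreadable from compound 1 to compound 2 cannot be read, since both values sit at the limit of > 100000 nM in this assay, at which 2 of the 2 values shown sit. Compound 3 `COc1cc(-c2nnc3n2NC(c2ccco2)C(C(=O)c2cccc4ccccc24)S3)cc(OC)c1OC` differs from compound 2 by naphthalen-1-yl in place of 4-methylphenyl on a carbonyl carbon. Going by the values given here, no measured step bears on this change. The expected step of a number no higher from compound 2 to compound 3 (the limit leaves the size open) is accordingly not readable beyond the scatter. Compound 3 is estimated at 100000 nM (range 30000 nM to 300000 nM) in this assay, most likely again reported only as a limit.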

Compound 3, half-maximal inhibitory concentration: > 100000 nM
Compound 3 ended at the assay's limit; the forecaster's own chance of this, stated with the estimate: 85%; the middle value lies on the limit itself.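

Going by these compounds alone, compound 1, compound 2 and compound 3 yield no new readable step, all three values being limits: the limit of > 100000 nM in this assay, at which 3 of the 3 values shown sit.
In this assay the compounds shown leave open how the groups on the carbonyl carbon rank, and which change, if any, would give a measurable value.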